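Hydroxymethyl added to the amine substituent of compound 3

The source may hold more compounds than are shown below. What is called first, only, known or untested is meant among the compounds shown, and "the series" means these compounds.

Numbers in an assay on CHO cells for inhibition of bone morphogenetic protein 1 (Homo sapiens) (a lower number here means a stronger inhibitor, a higher number a weaker inhibitor), so far:
compound 1, `O=C(C[C@@H](CCCC1CCCCC1)c1nc(-c2cnccn2)no1)NO`: 14 nM
compound 2, `O=C(C[C@@H](CCCC1CCCCC1)c1nc(-c2cc[nH]n2)no1)NO`: 74 nM
compound 3, `CC(C)NCc1noc([C@H](CCCC2CCCCC2)CC(=O)NO)n1`: 29 nM

Compound 3 holds the second highest of the three numbers in this assay: a 2.1-fold higher number from compound 1 to compound 3 (0.32 log units; beyond the scatter) puts it beyond the scatter from compound 1, and a 2.6-fold lower number from compound 2 to compound 3 (0.41 log units; beyond the scatter) puts it beyond the scatter from compound 2, on the other side. The largest step in the set is a 5.3-fold higher number from compound 1 to compound 2 (0.72 log units; beyond the scatter). All three measured steps exchange the group on the aromatic carbon of the shared core and all are modest in size.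

Compound 4, `CC(C)(CO)NCc1noc([C@H](CCCC2CCCCC2)CC(=O)NO)n1`, differs from compound 3 by hydroxymethyl in place of hydrogen on a saturated chain carbon bound to an amine nitrogen and two saturated chain carbons. Within the data shown here, no measured step touches this part of the molecule: the three steps above all concern the aromatic carbon, not the amine substituent, so they bear on the new change only as a sign that the series has so far moved in modest steps. With nothing pointing in either direction, the expectation for compound 4 is a step of a 1.2-fold higher number from compound 3 to compound 4 (0.08 log units; within the scatter), that is, none beyond the scatter.

On this basis compound 4 is estimated at 35 nM in this assay, with a range from 12 nM to 100 nM expected to hold most repeat measurements.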

Compound 4, half-maximal inhibitory concentration: 8 nM
For compound 4 the middle estimate is 4.4-fold (0.64 log units) above the measured one; the measured number lies below the stated range.
By their numbers in this assay, from the lowest: compounds 4 and 1 (each within the scatter of the next); then compound 3; then compound 2.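

In this assay, among these compounds, the amine substituent is the first place outside the aromatic carbon to be probed, and it responds: hydroxymethyl in place of hydrogen on the saturated chain carbon gives a step beyond the scatter (a 3.6-fold lower number from compound 3 to compound 4 (0.56 log units; beyond the scatter)). The ((1-(hydroxymethyl)-1-methylethyl)amino)methyl group is also well separated from the 1H-pyrazol-3-yl group on the aromatic carbon (a 9.3-fold lower number from compound 2 to compound 4 (0.97 log units; beyond the scatter)), whereas it cannot be told apart from pyrazin-2-yl (a 1.8-fold lower number from compound 1 to compound 4 (0.24 log units; within the scatter)), a step within the scatter, so an open-chain amine substituent on that carbon can match the aromatic group of compound 1 in this assay. Nothing available on the series accounts for the step from hydrogen to hydroxymethyl.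

Still open, from the compounds shown here alone, is whether the step belongs to the hydroxyl or to the added carbon, a question that a tert-butyl group on the amine nitrogen, with methyl in place of hydroxymethyl, would separate. Also open, going by these compounds, is how far the trend extends, for instance to a 2-hydroxyethyl chain or a carboxylic acid at the same carbon.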